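Swapping bromo for chloro on the shared core

The source may report more compounds than this note shows. Statements on the series, on what has been measured and on what is new or still open speak of the compounds shown alone.

Of the compounds shown here, two with a shared core have been measured. Within the data shown here, compound 1 `COc1ccc(C2=NN(C3=NC(=O)/C(=C4\C(=O)Nc5ccc(Cl)cc54)S3)C(c3ccc(OC)cc3)C2)cc1` and compound 2 `COc1ccc(C2=NN(C3=NC(=O)/C(=C4\C(=O)Nc5ccc(Br)cc54)S3)C(c3ccc(Cl)cc3)C2)cc1` differ in more than one place, so no single step can be counted between them. In a functional assay on cells (Cancer cell lines, Homo sapiens) for cytotoxicity, read by sulforhodamine B assay, with a stated time of 48 h (a lower number here means a stronger inhibitor of growth, a higher number a weaker inhibitor of growth), compound 2 gives 190 nM, and in this assay compound 1 gives 230 nM; the gap between these two numbers lies within the usual scatter, so neither can be called the stronger one.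

Compound 3 `COc1ccc(C2=NN(C3=NC(=O)/C(=C4\C(=O)Nc5ccc(Cl)cc54)S3)C(c3ccc(Cl)cc3)C2)cc1` has not yet been measured. It keeps the core of compound 2 and changes a single spot: chloro in place of bromo on an aromatic carbon. Among the measured compounds shown here, the two halogens are close relatives, and the only measured pair offers no isolated step to lean on, so there is no basis for expecting a move beyond the scatter in either direction.

The estimate for compound 3 in this assay is therefore 210 nM, with a range from 100 nM to 450 nM. This estimate means a step of a 1.1-fold higher number from compound 2 to compound 3 (0.04 log units; within the scatter) that is expected to stay within the ordinary variation of repeated measurements.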

Compound 3, concentration for 50% growth inhibition: 270 nM
Compound 3: middle estimate off by 1.3-fold (0.11 log units), on the low side; low and high end bracket the measured number.
By their numbers in this assay, from the lowest: compounds 2, 1 and 3 (each within the scatter of the next).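

In this assay, the shared core now has its first steps that change a single place, and both stay within the scatter. Chloro in place of bromo, on an aromatic carbon of the fused system of two rings, gives a 1.4-fold higher number from compound 2 to compound 3 (0.15 log units; within the scatter) and so shows that this assay cannot tell these two halogens apart at this position. Chloro in place of methoxy, at a second spot on an aromatic carbon, gives a 1.2-fold higher number from compound 1 to compound 3 (0.07 log units; within the scatter) and so shows that even a swap between less closely related groups leaves the number within the scatter there, though no measurement of any property of these groups comes with these numbers to account for either result.

From the compounds shown here alone, both steps involve only chloro, bromo and methoxy, so it remains open whether a group of another kind, such as an amine or a carboxylic acid, on the aromatic carbon that carries the halogen would move the number beyond the scatter. Going by these compounds, it is equally open whether a longer chain in place of the methoxy would do so.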